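This account rests on a few compounds, and the source may have more. Where it says the series, first, only, none or still open, it means among the compounds named here.

Of the compounds shown here, two have been measured in an assay on CHO cells for displacement of a labelled ligand from Alpha-2B adrenergic receptor (Homo sapiens) (a higher number here means a weaker inhibitor, a lower number a stronger inhibitor), so far. Compound 1 `CC(Oc1ccccc1-c1cccnc1)C1=NCCN1` gives 933 nM. Compound 2 `CC(Oc1ccccc1-c1ccccc1)C1=NCCO1` gives 10000 nM, the higher of the two numbers; the gap between compound 1 and compound 2 lies beyond the usual scatter, so compound 2 is the weaker binder of the pair as measured. Compound 3 `CC(Oc1ccccc1-c1ccccc1)C1=NCCS1` has not yet been measured in this assay. It differs from compound 2 in one place: a group of 5 heavy atoms (3 carbon, 1 nitrogen, 1 sulfur; one five-membered non-aromatic ring with 2 hetero atoms) in place of a group of 5 heavy atoms (3 carbon, 1 nitrogen, 1 oxygen; one five-membered non-aromatic ring with 2 hetero atoms), on a saturated chain carbon bound to an oxygen on an aromatic ring and a saturated chain carbon. Everything else in the structure is kept as in compound 2. Among the measured compounds shown here, no measured pair shows this exchange, so the size of the step rests on the change alone. The expected step is a 2.0-fold lower number from compound 2 to compound 3 (0.30 log units; within the scatter), toward a somewhat lower number, at most just beyond the scatter. Compound 3 is estimated at 5000 nM, with a range from 1500 nM to 15000 nM.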

Compound 3, inhibition constant: < 10000 nM
Compound 3 was reported as a limit; the forecaster's own chance of this, stated with the estimate: 25%; the middle value does not contradict the limit.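

In this assay compound 3 gives < 10000 nM, which is a limit of the assay and not a number. The exchange of the oxygen-containing ring for the sulfur-containing ring gives a number no higher from compound 2 to compound 3 (the limit leaves the size open) and the size of this step cannot be read, so this position gains a first tested change but no size for it. The reading of this change rests on that limit alone: the limit of < 10000 nM in this assay, at which 1 of the 3 values shown sits.

Compound 1 differs from compound 2 and compound 3 in more than one place, so it does not settle what the ring on this saturated chain carbon contributes. Open too, going by these compounds, is what an amine or a carboxylic acid on this carbon, in place of the five-membered ring, would give in this assay.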